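Bromine Added to the Core of a Sulfonamide Series

The source may report more compounds than this note shows. Statements on the series, on what has been measured and on what is new or still open speak of the compounds shown alone.

Measured compounds:
compound 1 `Cc1cc(S(N)(=O)=O)ccc1NC(=O)COc1ccc2ccccc2c1C(=O)c1ccccc1` – 33800 nM
compound 2 `Cc1cc(S(N)(=O)=O)ccc1NC(=O)COc1ccc2ccccc2c1C(=O)c1cccc(Cl)c1` – 37400 nM
compound 3 `Cc1cc(S(N)(=O)=O)ccc1NC(=O)COc1ccc2ccccc2c1C(=O)c1cc(Cl)cc(Br)c1` – 36600 nM

Three compounds were tested in an ADME assay on C8166 cells (Homo sapiens) for cytotoxicity, read by colorimetric assay and MTT assay; on this read-out lower numbers stand for higher toxicity in this test and higher numbers for lower toxicity in this test. Compound 1 sits in a tight group with compound 2 and compound 3; its gaps to both lie within the scatter, as a 1.1-fold higher number from compound 1 to compound 2 (0.04 log units; within the scatter) and a 1.1-fold higher number from compound 1 to compound 3 (0.03 log units; within the scatter) show. Compound 4 `Cc1cc(S(N)(=O)=O)ccc1NC(=O)COc1ccc2cc(Br)ccc2c1C(=O)c1ccccc1` differs from compound 1 by bromo in place of hydrogen on an aromatic carbon. Both measured steps that bear on it, halogens placed on an aromatic ring in a 1.1-fold higher number from compound 1 to compound 2 (0.04 log units; within the scatter) and a 1.1-fold higher number from compound 1 to compound 3 (0.03 log units; within the scatter), were within the scatter. Within the data shown here, no measured step touches this ring of the shared core, so the expectation rests on those two steps alone. Compound 4 is therefore expected to show a step of a 1.0-fold higher number from compound 1 to compound 4 (0.02 log units; within the scatter) in this assay, none beyond the scatter. The estimate for compound 4 is 35000 nM, ranging from 18000 nM to 68000 nM.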

Compound 4, half-maximal cytotoxic concentration: 29200 nM
Estimate against measurement, compound 4: 1.2-fold (0.08 log units) above; measured number inside the range.
By their numbers in this assay, from the lowest: compounds 4, 1, 3 and 2 (each within the scatter of the next).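

With bromo in place of hydrogen on this ring of the shared core, part of a fused system of two rings, this assay gives a 1.2-fold lower number from compound 1 to compound 4 (0.06 log units; within the scatter). Among these compounds, this is the first reading at this position, and the change leaves the number within the scatter here too. The same change reads alike on both cores: the same change on two cores in this assay, a 1.0-fold lower number (0.01 log units; within the scatter) from compound 2 to compound 3 and a 1.2-fold lower number (0.06 log units; within the scatter) from compound 1 to compound 4, 1.1-fold (0.05 log units) apart, within the scatter of two such steps

The compounds shown leave open whether an amine or a carboxylic acid at this position would also stay within the scatter, and whether bromo on the ring's other carbons would.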